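The source may hold more compounds than are shown below. What is called first, only, known or untested is meant among the compounds shown, and "the series" means these compounds.

Three compounds of the series have been measured so far in a functional assay for inhibition, read by Griess assay, with a stated time of 150 min, tested at 1 mM; a lower number here means less inhibition, a higher number more inhibition at the concentration tested (going by the name of the read-out):

- compound 1, `COc1ccc2[nH]cc(C(=O)/C(C#N)=C/C=C(\Cl)c3ccc(Br)cc3)c2c1`: compound 1 gives 76.7%
- compound 2, `N#C/C(=C\C=C(/Cl)c1ccc(Br)cc1)C(=O)c1c[nH]c2ccccc12`: compound 2 gives 76.7%
- compound 3, `COc1ccc(/C(Cl)=C/C=C(\C#N)C(=O)c2c[nH]c3ccccc23)cc1`: compound 3 gives 76.9%

All three numbers lie within the usual scatter of one another, so no order among them can be read from this assay. The pair compound 2 and compound 1 differs by methoxy in place of hydrogen on an aromatic carbon, and the step is no change at the digits printed from compound 2 to compound 1 (within the scatter). The pair compound 2 and compound 3 differs by methoxy in place of bromo on an aromatic carbon; this is also how the core of compound 3 differs from the core of compound 2, and the step there is a number 0.2 percentage points higher from compound 2 to compound 3 (within the scatter).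

Compound 4, `COc1ccc(/C(Cl)=C/C=C(\C#N)C(=O)c2c[nH]c3ccccc23)cc1OC`, is not yet measured. It differs from compound 3 by methoxy in place of hydrogen on an aromatic carbon. Going by the values given here, this is the same kind of change as the one from compound 2 to compound 1, but not the same change: in the earlier pair the aromatic carbon is part of a fused or bridged system of two rings, meta to a fused ring and para to a fused ring, whereas in compound 4 it is ortho to a methoxy group and meta to a large group. The earlier instance gave no change at the digits printed from compound 2 to compound 1 (within the scatter). Beside that, the expected step for compound 4 is a number 0.1 percentage points higher from compound 3 to compound 4 (within the scatter), resting on the earlier step of no change at the digits printed from compound 2 to compound 1 (within the scatter) and on the three measured values all sitting within the scatter of each other. Among the compounds with values here, the range is kept wide since the surroundings of the change are not the same and only one prior instance exists. For compound 4 in this assay the estimate is 77%, with a likely span from 66% to 87%.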

Compound 4, a percentage reported as inhibition, at one concentration (the size of the read-out at that concentration, not a potency): 75%
Compound 4: the middle estimate sits 2 percentage points above what was measured; measured number inside the range.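

In this assay, methoxy in place of hydrogen on an aromatic carbon gives a number 1.9 percentage points lower from compound 3 to compound 4 (within the scatter), and this second instance does not separate from the first: the same change on two cores in this assay, no change at the digits printed (within the scatter) from compound 2 to compound 1 and a number 1.9 percentage points lower (within the scatter) from compound 3 to compound 4, 1.9 percentage points apart, within the scatter of two such steps.

As far as these two pairs go, the change carries from the core of compound 2 to the core of compound 3 without a step beyond the scatter, even though in compound 4 the new methoxy is ortho to a methoxy group and meta to a large group, which is not the setting of the earlier pair. This does not show that the change is without effect across the series: there are only two instances, each read at one concentration, and a percentage at one concentration is not a potency, so differences in potency could remain unseen.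

Open, on these data alone, is what an amine or a carboxylic acid would do on the aromatic ring that carries bromo or methoxy in these compounds, since only those two groups and the added methoxy appear there. Also open, as far as these compounds go, is whether the read-out holds when the nitrile or the chloro on the shared chain gives way to another group, such as an amide or a longer chain.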